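The compounds below may be only part of what the source reports. "The series", "measured", "known", "first", "only" and "open" are said of these compounds alone.

Working notes on the series.

Compound 1 `N=C(N)N/N=C/c1c(-c2cccs2)nc2sccn12` and compound 2 `Cc1cc(-c2nc3sccn3c2/C=N/NC(=N)N)c(C)s1` share one core; compound 3 `Cc1cc(-c2nc3n(c2/C=N/NC(=N)N)CCS3)c(C)s1` and the unmeasured compound 4 `N=C(N)N/N=C/c1c(-c2cccs2)nc2n1CCS2` share a second core. The difference between the two cores is not broken down here.

In a functional assay on cells (Cancer cell lines, Homo sapiens) for inhibition (a lower number here means a stronger inhibitor of growth, a higher number a weaker inhibitor of growth), compound 1 gives 28200 nM. In this assay compound 2 gives 30200 nM. The change from compound 2 to compound 1 is thiophen-2-yl in place of 2,5-dimethylthiophen-3-yl on an aromatic carbon, and it gave a 1.1-fold lower number from compound 2 to compound 1 (0.03 log units; within the scatter). In this assay compound 3 gives 41700 nM; its gaps to compound 2 and to compound 1 are both within the scatter, so no order among the three measured compounds can be read from these numbers.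

The change from compound 3 to compound 4 is thiophen-2-yl in place of 2,5-dimethylthiophen-3-yl on an aromatic carbon. It is the same kind of change as that from compound 2 to compound 1, not the same one: around the place on the core of compound 3 the carbon is also two ring bonds from two ring atoms that each bear a fused ring, which is not so on the core of compound 2. The same exchange of the thiophene occurs twice among the compounds shown, once measured.

For compound 4 the step expected in this assay is a 1.1-fold lower number from compound 3 to compound 4 (0.04 log units; within the scatter), resting on the step of compound 2 to compound 1 a 1.1-fold lower number from compound 2 to compound 1 (0.03 log units; within the scatter), which was within the scatter. Compound 4 is therefore estimated at 38000 nM in this assay, with a range from 19000 nM to 76000 nM.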

Compound 4, concentration for total growth inhibition: 40700 nM
Beside the measured number, compound 4's estimate is 1.1-fold (0.03 log units) below it; the range from low to high includes it.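

In this assay, going by these compounds alone, thiophen-2-yl in place of 2,5-dimethylthiophen-3-yl on the second core gave a 1.0-fold lower number from compound 3 to compound 4 (0.01 log units; within the scatter) and so, as on the first core, produced no step that can be told from the scatter. Set side by side, the two steps do not differ, and the exchange reads the same on both cores: the same change on two cores in this assay, a 1.1-fold lower number (0.03 log units; within the scatter) from compound 2 to compound 1 and a 1.0-fold lower number (0.01 log units; within the scatter) from compound 3 to compound 4, 1.0-fold (0.02 log units) apart, within the scatter of two such steps. This shows that, for this one exchange and these two pairs, the result on one core matched the result on the other, but it does not show that a step of real size would carry over in the same way, as neither pair offers such a step to follow from core to core.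

The compounds shown carry only these two thiophene groups on that aromatic carbon, so it remains open whether a group of another kind there, such as an amine, a carboxylic acid or a longer chain, would give a step beyond the scatter, and whether that step would then hold on both cores. Also open, as far as these compounds go, is whether the same agreement between the cores would appear in any read-out other than this assay.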